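A few compounds are considered here, and "the series" means these few. Any claim that something is new, unique, unknown or untested is made for them only; others in the source may bear on it.

Measured compounds:
compound 1, `CC1=CC[C@@H]([C@@](C)(O)CCCC(C)(C)NC=S)CC1`: 16700 nM
compound 2, `CC1=CC[C@@H]([C@@](C)(O)CCCC(C)(C)NC(=S)NN)CC1`: 760 nM

Both were tested in a functional assay on NCI/ADR cells (Homo sapiens) for cytotoxicity, read by sulforhodamine B assay; a higher number here means a weaker inhibitor of growth, a lower number a stronger inhibitor of growth. Going by the values given here, compound 2 holds the lower of these two numbers; the nearest to it is compound 1, and the only step on record is a 22-fold lower number from compound 1 to compound 2 (1.34 log units; beyond the scatter), a large one, made by putting an aminoamino group onto the thiocarbonyl carbon.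

Compound 3, `CC1=CC[C@@H]([C@@](C)(O)CCCC(C)(C)NC(=S)N/N=C\c2ccccc2)CC1`, carries the change (a group of 8 heavy atoms (7 carbon, 1 nitrogen; one six-membered aromatic ring of carbon only) in place of one nitrogen atom, on an amide-type nitrogen). Among the compounds with values here, no measured step covers a change of this kind. Within the data shown here, the one step known bears on it only indirectly: what sits on the thiocarbonyl carbon mattered strongly in this assay because of a 22-fold lower number from compound 1 to compound 2 (1.34 log units; beyond the scatter). The present change keeps that nitrogen attached and extends it. The step from compound 2 to compound 3 is therefore expected to be modest, leaning towards a lower number. The value expected for compound 3 is 400 nM, with a range from 100 nM to 2000 nM. That estimate means a step of a 1.9-fold lower number from compound 2 to compound 3 (0.28 log units; within the scatter).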

Compound 3, concentration for 50% growth inhibition: 6970 nM
Compound 3: middle estimate off by 17-fold (1.24 log units), on the low side; measured number above the stated range.
By their numbers in this assay, from the lowest: compound 2; then compound 3; then compound 1.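

In this assay, extending the amino group into a group of 8 heavy atoms carrying a six-membered aromatic ring gives back much of what the amino group had gained, with a 9.2-fold higher number from compound 2 to compound 3 (0.96 log units; beyond the scatter). Part of the gain remains, with a 2.4-fold lower number from compound 1 to compound 3 (0.38 log units; beyond the scatter), so the larger group still does better than hydrogen on the thiocarbonyl carbon, while the plain amino group gives the lowest number of the three. Nothing available explains why the larger group costs so much.

On these data alone, it remains open whether a small group on the same nitrogen, such as a methyl or an ethyl chain, would stay close to compound 2 or fall towards compound 3. A saturated carbon chain of similar length would help show whether the aromatic ring or simply the size of the group sets this number.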